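The source may report more compounds than this note shows. Statements on the series, on what has been measured and on what is new or still open speak of the compounds shown alone.

Measured compounds:
Compound 1, `CC(=O)N1CCN(c2nc(Nc3ccc(C#N)c(C(F)(F)F)c3)nc(Oc3ccnc4ccccc34)n2)CC1`, in a functional assay on DU-145 cells (Homo sapiens) for cytotoxicity, read by sulforhodamine B assay, with a stated time of 48 h; on this read-out higher numbers stand for weaker inhibition of growth and lower numbers for stronger inhibition of growth: 75100 nM
Compound 2, `N#Cc1ccc(Nc2nc(Oc3ccnc4ccccc34)nc(N3CCN(c4ccccn4)CC3)n2)cc1C(F)(F)F`, in this assay: 85900 nM

Compound 2 gives one of only two numbers available, and its neighbour is compound 1: the step of a 1.1-fold higher number from compound 1 to compound 2 (0.06 log units; within the scatter) lies within the usual scatter, so the two compounds cannot be told apart on this read-out, and compound 2 stands nowhere in particular on the numbers shown.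

Compound 3, `N#Cc1ccc(Nc2nc(Oc3ccnc4ccccc34)nc(N3CCN(c4ccccc4F)CC3)n2)cc1C(F)(F)F`, is not yet measured. It differs from compound 2 in one place: 2-fluorophenyl in place of pyridin-2-yl on an amine nitrogen in a ring, the group sitting on an amine nitrogen in a ring of a six-membered non-aromatic ring with 2 nitrogen.

Among the measured compounds shown here, only one measured step touches that same ring nitrogen, the exchange of acetyl for pyridin-2-yl from compound 1 to compound 2, and it was within the scatter. A second exchange at that nitrogen therefore gives no reason to expect a step beyond the scatter in either direction. Compound 3 is accordingly estimated at 80000 nM in this assay, with a range from 40000 nM to 160000 nM. The expected step from compound 2 to compound 3 is a 1.1-fold lower number from compound 2 to compound 3 (0.03 log units; within the scatter).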

Compound 3, concentration for 50% growth inhibition: > 100000 nM
Compound 3: only a limit was reported; the forecaster's own chance of this, stated with the estimate: 20%; middle value at least 1.2-fold (0.09 log units) from the limit.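

In this assay compound 3 is reported only as a limit, > 100000 nM, which is a limit of the assay and not a number. On these data alone, with 2-fluorophenyl on the amine nitrogen in the ring, the reading is an at least 1.1-fold higher number from compound 2 to compound 3 (0.06 log units; that floor lies within the scatter), and against the acetyl group it is an at least 1.3-fold higher number from compound 1 to compound 3 (0.12 log units; that floor lies within the scatter), so neither floor separates the new compound from the earlier two, and the true size of both steps stays unknown. What the result adds is a third group on that amine nitrogen, a carbon-only aromatic ring bearing fluorine in place of a ring with a nitrogen, and the first reading at the top of the measured range: the limit of > 100000 nM in this assay, at which 1 of the 3 values shown sits.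

As far as these compounds go, it remains open whether a plain phenyl ring, an aliphatic amine, a carboxylic acid or a longer alkyl chain on that ring nitrogen would move the number beyond the scatter in either direction. Also open, from the compounds shown here alone, is how far past its limit compound 3 actually lies, and so whether the exchange of pyridin-2-yl for 2-fluorophenyl has any real effect on growth inhibition in these cells.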